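A few compounds are considered here, and "the series" means these few. Any claim that something is new, unique, unknown or untested is made for them only; others in the source may bear on it.

Measured compounds in hand:
- compound 1 `CC(=O)N1N=C(c2ccc(-n3c(C)ccc3C)cc2)OC1c1ccc(Br)cc1`; in an ADME assay on Vero cells (Chlorocebus sabaeus) for cytotoxicity, read by MTT assay, with a stated time of 72 h (on this read-out lower numbers stand for stronger inhibition and higher numbers for weaker inhibition), compound 1 gives 195000 nM
- compound 2 `O=C(NNC(=O)c1ccc([N+](=O)[O-])cc1)c1ccc(-n2cccc2)cc1`; in this assay compound 2 gives 190000 nM
- compound 3 `Cc1ccc(C)n1-c1ccc(C(=O)N/N=C/c2ccccc2)cc1`; in this assay compound 3 gives "not determined" (no result reported), that is, no result was reported for compound 3

On the two numbers available, compound 1 stands highest, but its nearest neighbour, compound 2, lies within the scatter of it, so the two cannot be ordered and neither can be called more or less cytotoxic than the other. Compound 3 adds no number. Both values sit at the high end of the concentration range, meaning weak inhibition of Vero cell viability for the pair.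

Among the measured compounds shown here, no step between measured compounds that differ in one place is available, so the move to compound 4 `CC(=O)N1N=C(c2ccc(-n3c(C)ccc3C)cc2)OC1c1ccc(O)cc1` has no measured analogue in this set. The change is hydroxy in place of bromo on an aromatic carbon. For the measured compounds named here, with both measured compounds sitting close together and no single-point step to lean on, the expectation is a step of no size beyond the scatter in this assay, in either direction.

Compound 4 is therefore expected to give about 210000 nM in this assay, with a plausible range from 110000 nM to 400000 nM. That estimate corresponds to a step of a 1.1-fold higher number from compound 1 to compound 4 (0.03 log units; within the scatter), expected to lie within the scatter.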

Compound 4, half-maximal inhibitory concentration: 187000 nM
For compound 4 the middle estimate is 1.1-fold (0.05 log units) above the measured one, and the stated range covers the measured number.
By their numbers in this assay, from the lowest: compounds 4, 2 and 1 (each within the scatter of the next).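

Among the compounds shown here, the change from 4-bromophenyl to 4-hydroxyphenyl on the core of compound 1 gives the first one-place step: in this assay there is a 1.0-fold lower number from compound 1 to compound 4 (0.02 log units; within the scatter) and so no change that this read-out can resolve. The earlier compounds shown here offered no such step, and this one shows that, at this position on the six-membered aromatic ring, para to a large group, hydroxy can take the place of bromo with the read-out staying in the same high range, even though a hydrogen-bond donor and a hydrogen-bond acceptor enter with it. Nothing measured here accounts for this lack of a resolvable step.

With only bromo and hydroxy shown at this position, it remains open whether an amine, a carboxylic acid or a longer chain such as butoxy would produce a step beyond the scatter or leave the read-out where it stands. For the compounds shown here, it is also open whether the same exchange would behave alike on a core other than that of compound 1, since this single pair is the only one-place comparison available.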